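Ethyl in Place of Acetyl on the Shared Core

This account rests on a few compounds, and the source may have more. Where it says the series, first, only, none or still open, it means among the compounds named here.

Compound 3 `CC(=O)c1ccc(/C=C/[C@@H]2CCCCN2)cc1` was tested in a functional assay on MCF7 cells (Homo sapiens) for inhibition, read by MTT assay, with a stated time of 24 h (a higher number here means a weaker inhibitor, a lower number a stronger inhibitor), where compound 3 gave 2.7 ug/mL. Among the three compounds measured so far, compound 3 holds the second highest number: compound 2 `COc1ccccc1/C=C/[C@@H]1CCCCN1` gave 3.81 ug/mL, and compound 1 `CN1CCCC[C@H]1/C=C/c1ccc(O)cc1` gave 1.51 ug/mL, both within the scatter of compound 3. Compound 4 `CCc1ccc(/C=C/[C@@H]2CCCCN2)cc1` has not yet been measured. It differs from compound 3 in one place: ethyl in place of acetyl on an aromatic carbon. Among the compounds with values here, no step between measured compounds shows how this change acts, and the three known values sit close together. The expected step is a 1.1-fold higher number from compound 3 to compound 4 (0.05 log units; within the scatter), not beyond the scatter. Compound 4 is estimated at 3 ug/mL, with a range from 1.5 ug/mL to 6 ug/mL.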

Compound 4, half-maximal inhibitory concentration: 4.13 ug/mL
The estimate for compound 4 lay 1.4-fold (0.14 log units) below the measured number, within the range that was stated.
By their numbers in this assay, from the lowest: compounds 1, 3, 2 and 4 (each within the scatter of the next, the first and the last beyond it).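

At this position, ethyl in place of acetyl gives a 1.5-fold higher number from compound 3 to compound 4 (0.18 log units; within the scatter) in this assay, so the two compounds cannot be told apart in this assay, although the entering ethyl lacks the carbonyl oxygen and the hydrogen-bond acceptor of the leaving acetyl. This single step therefore shows no requirement for that acceptor at this position on the shared core. No measurement at hand explains the result. The compounds shown leave open whether an amine or a carboxylic acid at this position, or a longer chain, would move the number beyond the scatter of compound 3.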